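The source may hold more compounds than are shown below. What is called first, only, known or untested is meant among the compounds shown, and "the series" means these compounds.

Measured so far in a functional assay on PC-3 cells (Homo sapiens) for antiproliferative activity, read by sulforhodamine B assay, with a stated time of 48 h; on this read-out higher numbers stand for weaker inhibition and lower numbers for stronger inhibition:
- compound 1 `O=C(CCCCCCN1C(=O)/C(=N\O)c2cc([N+](=O)[O-])ccc21)NO`: 19700 nM
- compound 2 `Cc1ccc2c(c1)/C(=N/O)C(=O)N2CCCCCCC(=O)NO`: 620 nM
- compound 3 `CO/N=C1/C(=O)N(CCCCCCC(=O)NO)c2ccccc21`: 1670 nM

Compound 3 holds the middle place of these three numbers, higher than compound 2 and lower than compound 1. The next compound, compound 4 `CO/N=C1/C(=O)N(CCCCCCC(=O)NO)c2ccc(F)cc21`, keeps the structure of compound 3 apart from one change: fluoro in place of hydrogen on an aromatic carbon.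

Among the compounds with values here, only one measured step bears on this change. It is a 32-fold lower number from compound 1 to compound 2 (1.50 log units; beyond the scatter), with methyl in place of nitro on an aromatic carbon. That large step shows that a single swap on an aromatic carbon can move the number a long way. It involves neither fluoro nor hydrogen, however, so it gives no direction for compound 4. Within the data shown here, no measured pair shows what fluoro does here, so only a small shift in this assay is expected, quite possibly none beyond the scatter.

The expected step is a 1.2-fold lower number from compound 3 to compound 4 (0.08 log units; within the scatter). For compound 4 the estimate is 1400 nM, with an expected range of 600 nM to 3300 nM.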

Compound 4, half-maximal inhibitory concentration: 1150 nM
Compound 4: middle estimate off by 1.2-fold (0.09 log units), on the high side, and the stated range covers the measured number.
By their numbers in this assay, from the lowest: compounds 2, 4 and 3 (each within the scatter of the next, the first and the last beyond it); then compound 1.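

In this assay fluoro in place of hydrogen on this aromatic carbon gives a 1.5-fold lower number from compound 3 to compound 4 (0.16 log units; within the scatter) and so leaves the number inside the usual scatter. Within the data shown here, this is the first measured pair with hydrogen as the starting point on the ring, and it shows that this position accepts a fluorine atom without a clear gain or loss. The earlier step of a 32-fold lower number from compound 1 to compound 2 (1.50 log units; beyond the scatter) showed that a swap on an aromatic carbon can matter greatly, but the fluoro swap, unlike that one, produces no change beyond the scatter. Nothing measured here speaks to the reason for this result.

Still open, as far as these compounds go, is whether a larger group on this carbon, such as chloro, methoxy or an amine, would move the number beyond the scatter on the core of compound 3. Also open, from the compounds shown here alone, is whether fluoro would behave the same way in a compound carrying the free oxime hydroxyl of compound 2.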